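Benzyl ether on the aryl oxygen of compound 1

The compounds below may be only part of what the source reports. "The series", "measured", "known", "first", "only" and "open" are said of these compounds alone.

Compound 1 `CCN(CC)C(=O)Cc1c(-c2ccc(OC(C)C)cc2)nn2c(C)cc(C)nc12` is the reference point of this set. Among the measured compounds shown here, in an assay on isolated protein (kidney, strain Wistar) for displacement of a labelled ligand from Translocator protein (Rattus norvegicus), read by scintillation counting, with a stated time of 90 min (a lower number here means a stronger inhibitor, a higher number a weaker inhibitor), compound 1 gives 2.2 nM, the highest of the three numbers measured so far. Compound 2 `CCN(CC)C(=O)Cc1c(-c2ccc(OC3CCC3)cc2)nn2c(C)cc(C)nc12` gives 0.86 nM and compound 3 `CCN(CC)C(=O)Cc1c(-c2ccc(OCC3CCCC3)cc2)nn2c(C)cc(C)nc12` gives 2.1 nM. The step of a 2.6-fold lower number from compound 1 to compound 2 (0.41 log units; beyond the scatter) is modest, while a 1.0-fold lower number from compound 1 to compound 3 (0.02 log units; within the scatter) lies within the scatter, and a 2.4-fold higher number from compound 2 to compound 3 (0.39 log units; beyond the scatter) is again modest.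

Compound 4 `CCN(CC)C(=O)Cc1c(-c2ccc(OCc3cccc(C(F)(F)F)c3)cc2)nn2c(C)cc(C)nc12` differs from compound 1 by 3-(trifluoromethyl)benzyl in place of isopropyl on an oxygen on an aromatic ring. Both measured steps at this oxygen bear on the question: cyclobutyl in place of isopropyl gave a modestly lower number, cyclopentylmethyl in place of isopropyl gave no change beyond the scatter. For the measured compounds named here, the group entering here is larger than either and carries a trifluoromethyl, for which the set holds no measured step. For compound 4 the expected step is a 1.1-fold lower number from compound 1 to compound 4 (0.04 log units; within the scatter), not beyond the scatter. Compound 4 is estimated at 2 nM, with a range from 0.6 nM to 6.5 nM.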

Compound 4, inhibition constant: 0.67 nM
Compound 4: the middle estimate sits 3.0-fold (0.47 log units) above what was measured; the measured number falls inside the stated range.
By their numbers in this assay, from the lowest: compounds 4 and 2 (each within the scatter of the next); then compounds 3 and 1 (each within the scatter of the next).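

Among the compounds shown here, at the oxygen on an aromatic ring, the larger 3-(trifluoromethyl)benzyl is accepted in this assay and gives a 3.3-fold lower number from compound 1 to compound 4 (0.52 log units; beyond the scatter) and a 3.1-fold lower number from compound 3 to compound 4 (0.50 log units; beyond the scatter) as modest steps; the second shows that, on the saturated chain carbon bound to that oxygen, 3-(trifluoromethyl)phenyl and cyclopentyl can be told apart, which the earlier compounds could not show. With a 1.3-fold lower number from compound 2 to compound 4 (0.11 log units; within the scatter) inside the scatter, cyclobutyl and 3-(trifluoromethyl)benzyl cannot be separated here, so heavy-atom count does not order these groups. Nothing shown gives a reason for these steps.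

As far as these compounds go, what the trifluoromethyl itself contributes stays open, as the benzyl ring is never seen without it or with a chlorine or methoxy group in its place. Also open, from the compounds shown here alone, is whether a basic amine or a carboxylic acid on this benzyl ring would be accepted.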